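Hydroxy to bromo across a level set of compounds

This account rests on a few compounds, and the source may have more. Where it says the series, first, only, none or still open, it means among the compounds named here.

Measured in a functional assay on cells (Erythrocyte, Rattus norvegicus) for inhibition, read by hemolysis, with a stated time of 1 h; on this read-out higher numbers stand for weaker inhibition and lower numbers for stronger inhibition:
compound 1 `COc1cc(OC)c(OC)cc1/C=C/C(=O)c1cc(Cl)ccc1O` gives 2.23 ug/mL in this set
compound 2 `COc1cc(OC)c(OC)cc1/C=C/C(=O)c1ccc(F)cc1` gives 2.22 ug/mL in this set
compound 3 `COc1cc(OC)c(OC)cc1/C=C/C(=O)c1ccc(O)cc1` gives 2.29 ug/mL in this set

Compound 3 (2.29 ug/mL) stands level with the other two, since no gap among the three exceeds the scatter. The next compound, compound 4 `COc1cc(OC)c(OC)cc1/C=C/C(=O)c1ccc(Br)cc1`, carries bromo in place of hydroxy on an aromatic carbon, para to a large group (bromo in place of hydroxy on an aromatic carbon). The nearest measured change is hydroxy in place of fluoro on an aromatic carbon (a 1.0-fold higher number from compound 2 to compound 3 (0.01 log units; within the scatter)). The two wider changes at the carbonyl carbon (a 1.0-fold higher number from compound 1 to compound 3 (0.01 log units; within the scatter); a 1.0-fold lower number from compound 1 to compound 2 (0.00 log units; within the scatter)) also stay within the scatter. For the measured compounds named here, no measured compound carries bromo, so that group itself is untested. Even so, no step beyond the scatter is expected in this assay, in either direction. The estimated step is small (a 1.0-fold higher number from compound 3 to compound 4 (0.00 log units; within the scatter)). For compound 4 the expected value is about 2.3 ug/mL (estimated range 1.5 ug/mL to 3.5 ug/mL).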

Compound 4, half-maximal inhibitory concentration: 2.3 ug/mL
Estimate against measurement, compound 4: no gap at the digits printed; low and high end bracket the measured number.
By their numbers in this assay, from the lowest: compounds 2, 1, 3 and 4 (each within the scatter of the next).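

In this assay, bromo in place of hydroxy at this spot, para to a large group, gives no step beyond the scatter (a 1.0-fold higher number from compound 3 to compound 4 (0.00 log units; within the scatter)), although the count there falls from one hydrogen-bond donor and one acceptor to none of either. Bromo also stays level with fluoro at the same place (a 1.0-fold higher number from compound 2 to compound 4 (0.02 log units; within the scatter)), and the wider change to 4-bromophenyl on the carbonyl carbon stays within the scatter too (a 1.0-fold higher number from compound 1 to compound 4 (0.01 log units; within the scatter)). Nothing at hand accounts for why these numbers stay so level.

The compounds shown leave open whether an amine, a carboxylic acid or a longer chain at this place would also stay level with these four in this assay. From the compounds shown here alone, all four keep the other end of the shared core unchanged, so whether a change there would shift the number also remains open.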